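From 3,4-Dimethoxyphenyl to 3,4-Dichlorophenyl: Expecting Compound 3

This account rests on a few compounds, and the source may have more. Where it says the series, first, only, none or still open, it means among the compounds named here.

Measured compounds:
compound 1, `COc1ccc(-c2cc3ccc(OCCCCCn4cc(CNC(=O)CCCCC5CCSS5)nn4)cc3oc2=O)cc1` — 52.8%
compound 2, `COc1ccc(-c2cc3ccc(OCCCCCn4cc(CNC(=O)CCCCC5CCSS5)nn4)cc3oc2=O)cc1OC` — 55%

In a functional assay on PC-12 cells (Rattus norvegicus) for cytotoxicity, read by MTT assay, with stated times of 3 h and 2 h, tested at 50 uM (a higher number here means a stronger effect of the compound at the concentration tested, a lower number a weaker effect), compound 1 gives 52.8% and compound 2 gives 55%. Compound 2 stands nearest compound 1, separated only by a number 2.2 percentage points higher from compound 1 to compound 2 (within the scatter), and that step is within the scatter, so the two cannot be told apart on these numbers.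

The unmeasured compound 3, `O=C(CCCCC1CCSS1)NCc1cn(CCCCCOc2ccc3cc(-c4ccc(Cl)c(Cl)c4)c(=O)oc3c2)nn1`, differs from compound 2 in one place: 3,4-dichlorophenyl in place of 3,4-dimethoxyphenyl on an aromatic carbon. Among the compounds with values here, the only measured step in this set, methoxy in place of hydrogen on an aromatic carbon, gave a number 2.2 percentage points higher from compound 1 to compound 2 (within the scatter); it concerns a different position and a far smaller change than the present one, and no measured pair exchanges a methoxy for a chlorine. The data therefore give no direct guide to this step. Within the data shown here, with the one step available lying within the scatter, the step of a number 1 percentage points lower from compound 2 to compound 3 (within the scatter) is estimated to be small and of uncertain direction. Compound 3 is expected to give 54%, within a range from 40% to 68%.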

Compound 3, a percentage reported as activity, at one concentration (the size of the read-out at that concentration, not a potency): 66.2%
Compound 3: middle estimate off by 12.2 percentage points, on the low side, and the stated range covers the measured number.
By their numbers in this assay, from the lowest: compounds 1 and 2 (each within the scatter of the next); then compound 3.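

In this assay, this aromatic carbon, two atoms from the ring oxygen, proves able to carry a change that moves the read-out beyond the scatter: 3,4-dichlorophenyl in place of 3,4-dimethoxyphenyl gives a number 11.2 percentage points higher from compound 2 to compound 3 (beyond the scatter), whereas the earlier methoxy step did not separate its two compounds. The same group in place of 4-methoxyphenyl gives a number 13.4 percentage points higher from compound 1 to compound 3 (beyond the scatter), so compound 3 stands clear of both methoxy-bearing compounds, and among these three compounds the exchange of methoxy for chlorine, not the number of methoxy groups, is what shows a difference. Nothing available explains why the chlorine-bearing ring gives the stronger effect at the concentration tested.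

The compounds shown leave open whether both chlorines are needed, since a phenyl bearing a single chlorine, or one bearing fluorine or a trifluoromethyl group, does not appear among them. They also leave open whether the step holds with an amine on the ring or with a longer chain in place of the pentyl linker.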